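Diaryl ether thiosemicarbazones: lipophilicity notes, step to compound 4

A few compounds are considered here, and "the series" means these few. Any claim that something is new, unique, unknown or untested is made for them only; others in the source may bear on it.

Compound 1 `Cc1cc(Oc2ccc(/C=N/NC(=S)Nc3ccc(F)cc3)cc2)ccc1Cl` is one of three measured members of this series. In a physicochemical assay for lipophilicity, in phosphate buffer, measured as octanol-water partition, with a stated time of 24 h (on this read-out higher numbers stand for higher lipophilicity and lower numbers for lower lipophilicity), compound 1 gives 6.07, which stands second highest of the three numbers. Compound 2 `Cc1cc(Oc2ccc(/C=N/NC(=S)Nc3ccccc3)cc2)ccc1Cl` gives 6.03, and the step of a number 0.04 log units lower from compound 1 to compound 2 (within the scatter) is within the scatter. Compound 3 `Cc1cc(Oc2ccc(/C=N/NC(=S)Nc3ccc(Cl)cc3)cc2)ccc1Cl` gives 6.59, and the step of a number 0.52 log units higher from compound 1 to compound 3 (beyond the scatter) is beyond the scatter, as is a number 0.56 log units higher from compound 2 to compound 3 (beyond the scatter).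

Compound 4 `Fc1ccc(NC(=S)N/N=C/c2ccc(Oc3ccccc3)cc2)cc1` is not yet measured. Relative to compound 1 the change is phenyl in place of 4-chloro-3-methylphenyl on an oxygen on an aromatic ring. Among the measured steps only the chloro substitutions bear on it: a chloro added to an aromatic carbon moved the value by a number 0.56 log units higher from compound 2 to compound 3 (beyond the scatter), and a chloro replacing fluoro by a number 0.52 log units higher from compound 1 to compound 3 (beyond the scatter). Removing a chloro from an aromatic carbon should therefore move the value by about as much in the opposite direction. Among the measured compounds shown here, no measured step covers the loss of the methyl, so that part of the change is not anchored in the data.

The value of compound 4 in this assay is expected to fall below that of compound 1 by a number 0.97 log units lower from compound 1 to compound 4 (beyond the scatter), a step beyond the scatter. The estimate for compound 4 is 5.1, within a range from 4.6 to 5.6.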

Compound 4, partition coefficient: 5.09
Estimate against measurement, compound 4: 0.01 log units above, and the stated range covers the measured number.
By their numbers in this assay, from the lowest: compound 4; then compounds 2 and 1 (each within the scatter of the next); then compound 3.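

In this assay the change to phenyl in place of 4-chloro-3-methylphenyl on an oxygen on an aromatic ring is a number 0.98 log units lower from compound 1 to compound 4 (beyond the scatter) and shows that this place also moves the read-out, whereas compound 1, compound 2 and compound 3 differ only in fluoro, hydrogen or chloro on an aromatic carbon elsewhere in the core. Among the compounds shown here, the fluoro of compound 1 stays in compound 4, so the whole step belongs to the 4-chloro-3-methylphenoxy to phenoxy difference, and in size it exceeds the chloro step a number 0.56 log units higher from compound 2 to compound 3 (beyond the scatter) even though it gives only one number for the chloro and the methyl taken together. Nothing on hand gives a measured reason for the size of this step.

The share of the chloro and the share of the methyl remain unseparated, since neither the 4-chlorophenyl nor the 3-methylphenyl group appears on this oxygen in the compounds shown. Also open, going by these compounds, is how the read-out responds when the phenyl carries an amine or a carboxylic acid, or when a longer chain such as n-butyl takes its place.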